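From 4-Bromobenzyl to 4-Methoxy-3-nitrobenzyl in Compound 3

A few compounds are considered here, and "the series" means these few. Any claim that something is new, unique, unknown or untested is made for them only; others in the source may bear on it.

In a functional assay on HCT-116 cells (Homo sapiens) for inhibition, read by CCK-8 assay, with a stated time of 48 h (a lower number here means a stronger inhibitor, a higher number a weaker inhibitor), compound 1 (`COc1ccc(CN(C(=O)CSC(=S)N2CCc3cc(OC)ccc32)c2cc(OC)c(OC)c(OC)c2)cc1`) gives 9810 nM while compound 2 (`COc1cc(N(Cc2ccc(Br)cc2)C(=O)CSC(=S)N2CCN(C(=O)OC(C)(C)C)CC2)cc(OC)c1OC`) gives 11400 nM and these two numbers lie within the usual scatter of each other. Compound 3 (`COc1ccc(CN(C(=O)CSC(=S)N2CCN(C(=O)OC(C)(C)C)CC2)c2cc(OC)c(OC)c(OC)c2)cc1[N+](=O)[O-]`) keeps the rest of compound 2 but carries 4-methoxy-3-nitrophenyl in place of 4-bromophenyl on a saturated chain carbon bound to an amide-type nitrogen. Going by the values given here, no measured pair shows this change, and compound 1 and compound 2 differ in more than one place, so the data offer no direct guide. In this assay a small move toward a lower number is expected, but none clearly beyond the scatter, and the estimated step is a 1.6-fold lower number from compound 2 to compound 3 (0.21 log units; within the scatter) on this limited basis. Compound 3 is estimated at 7000 nM with an expected range of 2000 nM to 22000 nM across repeated measurements.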

Compound 3, half-maximal inhibitory concentration: 980 nM
For compound 3 the middle estimate is 7.1-fold (0.85 log units) above the measured one; the measured number lies below the stated range.
By their numbers in this assay, from the lowest: compound 3; then compounds 1 and 2 (each within the scatter of the next).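

Going by these compounds alone, on a saturated chain carbon bound to an amide-type nitrogen, the aryl group turns out to matter: in this assay, 4-methoxy-3-nitrophenyl in place of 4-bromophenyl gives a 12-fold lower number from compound 2 to compound 3 (1.07 log units; beyond the scatter) and lifts the series clear of the scatter for the first time. Compound 1 and compound 2 differ in more than one place and could not show that this single position responds so strongly. Nothing shown here explains the size of this step.

As far as these compounds go, what stays open is whether the gain needs both the methoxy and the nitro group on the ring, or whether one of them alone would carry it. From the compounds shown here alone, it is also open whether an amine or a nitrile in place of the nitro group would hold the lower number in this assay on this position.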